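A few compounds are considered here, and "the series" means these few. Any claim that something is new, unique, unknown or untested is made for them only; others in the source may bear on it.

Working notes on the series. One shared core carries compound 1 `Fc1cccc(F)c1Cn1ccc2nc(-c3c(F)cccc3F)nc-2c1` and compound 2 `Fc1cccc(F)c1Cn1cccc2nc(-c3c(F)cccc3F)nc1-2`, and in compound 3 `COc1ccc(Cn2ccc3nc(-c4ccccc4)nc-3c2)cc1` the same core bears a methoxybenzyl and an unsubstituted phenyl. In an ADME assay on MDBK cells (Bos taurus) for cytotoxicity (a higher number here means that more compound is tolerated, a lower number that less compound is tolerated), compound 1 gives > 100000 nM, which is a limit of the assay and not a number. Compound 2 in this assay also gives only a limit, > 100000 nM. Compound 3 in this assay stands at a limit as well, > 100000 nM. Every value shown so far is the limit of > 100000 nM in this assay, at which 3 of the 3 values shown sit, so the numbers do not set compound 3 apart from compound 1 or compound 2 in either direction.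

Compound 4 `N#Cc1ccc(Cn2ccc3nc(-c4ccccc4)nc-3c2)cc1` differs from compound 3 by cyano in place of methoxy on an aromatic carbon. No step between two measured compounds is shown, so nothing measured bears directly on this exchange. The expected step is a number no higher from compound 3 to compound 4 (the limit leaves the size open), none beyond the usual scatter, because every measured value sits at the limit of > 100000 nM in this assay, at which 3 of the 3 values shown sit. Compound 4 is therefore expected at 100000 nM, within 50000 nM to 200000 nM, and most likely reported again only as a limit.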

Compound 4, half-maximal cytotoxic concentration: > 100000 nM
Compound 4: a limit, no number; the forecaster's own chance of this, stated with the estimate: 80%; the middle value lies on the limit itself.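

No step can be read between compound 3 and compound 4, because both stand at a limit and not a number in this assay: the limit of > 100000 nM in this assay, at which 4 of the 4 values shown sit.

The compounds shown leave open how cyano and methoxy compare in this assay, and whether any change to the shared core lowers the tolerated concentration.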